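Naphthyl for methoxyphenyl on a second pyrazoline core

This account rests on a few compounds, and the source may have more. Where it says the series, first, only, none or still open, it means among the compounds named here.

Measured compounds:
compound 1 `COc1ccc(C2=NN(C3=NC(=O)/C(=C4\C(=O)Nc5ccc(Br)cc54)S3)C(c3ccc(OC)cc3)C2)cc1`: 380 nM
compound 2 `COc1ccc(C2CC(c3ccc4ccccc4c3)=NN2C2=NC(=O)/C(=C3\C(=O)Nc4ccc(Br)cc43)S2)cc1`: 330 nM
compound 3 `COc1ccc(C2=NN(C3=NC(=O)/C(=C4\C(=O)Nc5ccccc54)S3)C(c3ccc(Cl)cc3)C2)cc1`: 100000 nM

In a functional assay on cells (Cancer cell lines, Homo sapiens) for cytotoxicity, read by sulforhodamine B assay, with a stated time of 48 h (a higher number here means a weaker inhibitor of growth, a lower number a stronger inhibitor of growth), compound 1 gives 380 nM and compound 2 gives 330 nM. The change between them is naphthalen-2-yl in place of 4-methoxyphenyl on a carbon with a double bond to nitrogen, and its step is a 1.2-fold lower number from compound 1 to compound 2 (0.06 log units; within the scatter). Compound 3 stands apart: in this assay compound 3 gives 100000 nM, far weaker than compound 1 and compound 2. The difference between the core of compound 3 and the core of compound 1 is not broken down here.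

Compound 4 `O=C1N=C(N2N=C(c3ccc4ccccc4c3)CC2c2ccc(Cl)cc2)S/C1=C1/C(=O)Nc2ccccc21` is not yet measured. It differs from compound 3 by naphthalen-2-yl in place of 4-methoxyphenyl on a carbon with a double bond to nitrogen. This is the same kind of change as from compound 1 to compound 2, though in compound 3 the ring atom two bonds away bears a 4-chlorophenyl group where in compound 1 it bears a 4-methoxyphenyl group. Because a 1.2-fold lower number from compound 1 to compound 2 (0.06 log units; within the scatter) lay within the scatter, the expected step is a 1.4-fold lower number from compound 3 to compound 4 (0.15 log units; within the scatter), modest at most. Compound 4 is estimated at 70000 nM in this assay, with a real chance that only a limit is reported.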

Compound 4, concentration for total growth inhibition: 42100 nM
The estimate for compound 4 lay 1.7-fold (0.22 log units) above the measured number; low and high end bracket the measured number.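

In this assay, naphthalen-2-yl in place of 4-methoxyphenyl gives a 2.4-fold lower number from compound 3 to compound 4 (0.38 log units; beyond the scatter). Set beside the step on the other core, the change carries over with no size difference that can be told apart: the same change on two cores in this assay, a 1.2-fold lower number (0.06 log units; within the scatter) from compound 1 to compound 2 and a 2.4-fold lower number (0.38 log units; beyond the scatter) from compound 3 to compound 4, 2.1-fold (0.31 log units) apart, within the scatter of two such steps. Among the compounds shown here, these two pairs show only that the step stays small on these two cores; they do not separate the contribution of the cores themselves or predict the step on any further core.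

Going by these compounds, it remains open whether a group of another kind on the carbon with a double bond to nitrogen, such as an amine, a carboxylic acid or a longer alkyl chain, would move the number further. On these data alone, replacing the 4-chlorophenyl group with such groups is equally open.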